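Swapping a fluorinated diol for a sulfur-bearing group

A few compounds are considered here, and "the series" means these few. Any claim that something is new, unique, unknown or untested is made for them only; others in the source may bear on it.

Of the compounds shown here, three sharing one core have been measured in an assay on cells (Hepatocyte) for inhibition of glucokinase regulatory protein (Mus musculus), with stated times of 20 min and 40 min; a lower number here means that less compound is needed, a higher number that more compound is needed for the effect. Compound 1, `CC#C[C@H]1CN(S(=O)(=O)c2ccc(N)nc2)CCN1c1ccc([C@@](O)(CO)C(F)(F)F)cc1`, gives 89 nM, the lowest of the two numbers reported. Compound 2, `CC#C[C@H]1CN(S(=O)(=O)c2ccc(N)nc2)CCN1c1ccc(C(O)(C(F)(F)F)C(F)(F)F)cn1`, gives 421 nM in this assay, a gap to compound 1 that lies beyond the usual scatter. For compound 3, `CC#C[C@H]1CN(S(=O)(=O)c2ccc(N)nc2)CCN1c1ncc(C(O)(C(F)(F)F)C(F)(F)F)s1`, this assay reports only a limit, > 12500 nM, rather than a number.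

Compound 4, `CC#C[C@H]1CN(S(=O)(=O)c2ccc(N)nc2)CCN1c1ccc(S(=O)(=NC)C(F)(F)F)cc1`, has not yet been measured in this assay. It differs from compound 1 on the six-membered aromatic ring of carbon only: a group of 8 heavy atoms (2 carbon, 1 nitrogen, 1 oxygen, 3 fluorine, 1 sulfur; no ring) in place of a group of 8 heavy atoms (3 carbon, 2 oxygen, 3 fluorine; no ring), on an aromatic carbon. Within the data shown here, no measured pair in this set shows the effect of such an exchange, so the expectation rests on compound 1 alone and on the fact that the core and the rest of the molecule are kept.

Compound 4 is expected to give about 110 nM in this assay, with a likely range from 30 nM to 450 nM. The expected step of a 1.2-fold higher number from compound 1 to compound 4 (0.09 log units; within the scatter) is estimated to stay within the usual scatter, in no clear direction.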

Compound 4, half-maximal effective concentration: 2060 nM
Beside the measured number, compound 4's estimate is 19-fold (1.27 log units) below it, outside the stated range (above it).
By their numbers in this assay, from the lowest: compound 1; then compound 2; then compound 4. At a limit, above all of these: compound 3.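

In this assay, this exchange is far from neutral: it gives a 23-fold higher number from compound 1 to compound 4 (1.36 log units; beyond the scatter). Both groups hold 8 heavy atoms and neither has a ring, so at this position, para to a large group, matching the size of the group does not keep the number low. The group that leaves has 2 hydrogen-bond donors and the group that enters has 0, but the two groups also differ in their atoms, and nothing measured here shows which difference accounts for the step.

The compounds shown leave open how an amine or a carboxylic acid would fare at this position in this assay. They also leave open whether the sulfur-bearing group would give a similar result on the aromatic ring of compound 2.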